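Propyl in Place of Isopropyl in a Silent Series

A few compounds are considered here, and "the series" means these few. Any claim that something is new, unique, unknown or untested is made for them only; others in the source may bear on it.

Compound 1 `CCCc1nnc(SC)n2c(CCC)nc(C)c12`: > 48000 nM, a limit.
Compound 2 `CSc1nncc2c(C)nc(C(C)C)n12`: > 48000 nM, a limit.
Compound 3 `Cc1nc(C(C)C)n2c(S)nncc12`: > 48000 nM, a limit.

In a functional assay for inhibition, with Homo sapiens as the target (on this read-out lower numbers stand for stronger inhibition and higher numbers for weaker inhibition), compound 1 reaches only the limit of the assay, not a number. Compound 2 likewise sits at the limit. Compound 3 sits at the limit too, so all three stand together at the limit of > 48000 nM in this assay, at which 3 of the 3 values shown sit. Among the compounds with values here, the one measured step, a step that the two limits leave unreadable from compound 2 to compound 3, runs between two limits and its size cannot be read. Compound 4 `CCCc1nc(C)c2cnnc(SC)n12` differs from compound 2 by propyl in place of isopropyl on an aromatic carbon. No readable step bears on this change. Compound 4 is therefore expected to stay at the limit as well, the expected step being a step that the limit leaves unreadable from compound 2 to compound 4, giving an estimate of 60000 nM with a range from 20000 nM to 200000 nM.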

Compound 4, half-maximal inhibitory concentration: > 48000 nM
Compound 4 was reported as a limit; the forecaster's own chance of this, stated with the estimate: 85%; the middle value does not contradict the limit.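

Compound 4, like compound 1 and compound 2, is reported only as a limit in this assay, so neither step leading to compound 4 can be read. The compounds shown leave open how strongly any of them inhibits, and so whether propyl and isopropyl differ at all: the limit of > 48000 nM in this assay, at which 4 of the 4 values shown sit.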